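A few compounds are considered here, and "the series" means these few. Any claim that something is new, unique, unknown or untested is made for them only; others in the source may bear on it.

Working notes on the series sharing the core of compound 1 `Cc1ccnc(NC(c2ccccc2F)c2ccc3cccnc3c2O)c1`. In an assay for inhibition of protein disulfide-isomerase (Homo sapiens), with a stated time of 1 h (on this read-out higher numbers stand for weaker inhibition and lower numbers for stronger inhibition), compound 1 gives 880 nM. Compound 2 `Cc1ccnc(NC(c2ccc(F)cc2)c2ccc3cccnc3c2O)c1` gives in this assay 140 nM, and the step of a 6.3-fold lower number from compound 1 to compound 2 (0.80 log units; beyond the scatter). Compound 3 `Cc1ccnc(NC(c2ccccc2)c2ccc3cccnc3c2O)c1`, the unsubstituted phenyl analogue, reaches only a limit of this assay and no number, namely < 200 nM. So compound 3 stands at the low edge of the numbers shown, its position fixed only by the limit of < 200 nM in this assay, at which 1 of the 3 values shown sits. Still, the step of an at least 4.4-fold lower number from compound 1 to compound 3 (0.64 log units; beyond the scatter), while the step that the limit leaves unreadable from compound 2 to compound 3.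

Compound 4 `Cc1ccnc(NC(c2cccc(F)c2)c2ccc3cccnc3c2O)c1` is not yet measured. It differs from compound 3 by fluoro in place of hydrogen on an aromatic carbon. The measured steps that bear on it are the ortho and para fluoro steps just given: the ortho fluoro of compound 1 weakened inhibition beyond the scatter, whereas the para fluoro of compound 2 left a step that cannot be read against the limit of compound 3. Among the measured compounds shown here, a meta fluoro is a third placing, with no direct precedent here. In this assay compound 4 is therefore expected to sit close to compound 3, the expected step being a number no lower from compound 3 to compound 4 (the limit leaves the size open), within or only modestly beyond the scatter. The estimate for compound 4 in this assay is 200 nM, with a range from 70 nM to 600 nM.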

Compound 4, half-maximal inhibitory concentration: 350 nM
Estimate against measurement, compound 4: 1.8-fold (0.24 log units) below; the measured number falls inside the stated range.
By their numbers in this assay, from the lowest: compound 2; then compound 4; then compound 1.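

In this assay the 3-fluorophenyl group completes the set of fluorophenyl isomers and separates from both others, with a 2.5-fold higher number from compound 2 to compound 4 (0.40 log units; beyond the scatter) and a 2.5-fold lower number from compound 1 to compound 4 (0.40 log units; beyond the scatter), so among compound 1, compound 2 and compound 4 the place of the fluoro on the ring orders the numbers, with the 4-fluorophenyl lowest and the 2-fluorophenyl highest. Compound 3 is fixed only by a limit of the assay, < 200 nM. Against that limit the change of hydrogen to fluoro gives only a floor, an at least 1.7-fold higher number from compound 3 to compound 4 (0.24 log units; that floor lies within the scatter), and the true size of this step stays unknown because compound 3 has no number of its own: the limit of < 200 nM in this assay, at which 1 of the 4 values shown sits.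

From the compounds shown here alone, the step between compound 2 and compound 3 cannot be read, so it remains open whether any fluoro placing matches the unsubstituted phenyl or whether all of them raise the number. Also open, going by these compounds, is whether this ordering belongs to fluoro alone or would hold for a chloro, a methoxy or a nitrile at the same places on the ring.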